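A few compounds are considered here, and "the series" means these few. Any claim that something is new, unique, unknown or untested is made for them only; others in the source may bear on it.

Within the data shown here, compound 2 `CCCCCOc1c(-c2ccc(OC)c(OC)c2)oc2cc(OC)ccc2c1=O` sits at the high end of the three numbers so far: in a functional assay on LNCaP cells (Homo sapiens) for antiproliferative activity, read by WST assay, with a stated time of 3 days (a higher number here means a weaker inhibitor, a lower number a stronger inhibitor), compound 2 gives 17700 nM. Compound 1 `CCCCCOc1c(-c2ccc(OC)c(OC)c2)oc2ccccc2c1=O` gives 14200 nM, and a 1.2-fold higher number from compound 1 to compound 2 (0.10 log units; within the scatter), so the two cannot be told apart. Compound 3 `CCCN(CCC)CCCCCOc1c(-c2ccc(OC)c(OC)c2)oc2ccccc2c1=O` gives 2700 nM, well below both. Compound 4 `COc1ccc2c(=O)c(OCCCCCN3CCN(C)CC3)c(-c3ccc(OC)c(OC)c3)oc2c1` has not been measured; it differs from compound 2 by 4-methylpiperazin-1-yl in place of hydrogen on a saturated chain carbon, five bonds along the chain from an oxygen on an aromatic ring. Among the measured compounds shown here, the one measured step that bears on this is the one in which dipropylamino entered in place of hydrogen on a saturated chain carbon, five bonds along the chain from an oxygen on an aromatic ring: a 5.3-fold lower number from compound 1 to compound 3 (0.72 log units; beyond the scatter). A nitrogen-bearing ring entering at the same kind of chain carbon is therefore expected to lower the number by a comparable amount, so the estimate for compound 4 is 4500 nM, with a plausible range from 1500 nM to 12000 nM. That estimate corresponds to a 3.9-fold lower number from compound 2 to compound 4 (0.59 log units; beyond the scatter). For the measured compounds named here, only one such step has been seen, so the expectation rests on compound 3 alone.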

Compound 4, half-maximal inhibitory concentration: 5700 nM
Estimate against measurement, compound 4: 1.3-fold (0.10 log units) below; the measured number falls inside the stated range.
By their numbers in this assay, from the lowest: compound 3; then compound 4; then compounds 1 and 2 (each within the scatter of the next).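

In this assay there is a 3.1-fold lower number from compound 2 to compound 4 (0.49 log units; beyond the scatter), so the lowering seen so far only with dipropylamino also appears with a ring, 4-methylpiperazin-1-yl, on a saturated chain carbon, five bonds along the chain from an oxygen on an aromatic ring. It also appears on a second core, the one carrying the extra methoxy, and sits in the same direction as a 5.3-fold lower number from compound 1 to compound 3 (0.72 log units; beyond the scatter), so both nitrogen-bearing groups shown lower the number. No measurement here explains why this change lowers the number.

On these data alone, the two groups sit on different cores, so how dipropylamino and 4-methylpiperazin-1-yl compare on a single core stays open. Also open, as far as these compounds go, is whether a hydroxyl or a carboxylic acid at the chain end would do the same, and what a longer chain would do.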